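Chloro to bromo on the thiourea aryl ring

The compounds below may be only part of what the source reports. "The series", "measured", "known", "first", "only" and "open" are said of these compounds alone.

Measured compounds:
compound 1 `NC(=O)c1c(NC(=O)c2ccccc2I)sc2c1CCN(C(=S)Nc1ccccc1Cl)C2` gives 8560 nM
compound 2 `Cc1ccccc1C(=O)Nc1sc2c(c1C(N)=O)CCN(C(=S)Nc1ccccc1Cl)C2` gives 20900 nM
compound 3 `NC(=O)c1c(NC(=O)c2cccc([N+](=O)[O-])c2)sc2c1CCN(C(=S)Nc1ccccc1Cl)C2` gives 7040 nM

These three compounds share one core and differ only in the aromatic group attached through the carbonyl carbon. In a functional assay on HL-60 cells (Homo sapiens) for antiproliferative activity, with a stated time of 24 h (on this read-out lower numbers stand for stronger inhibition and higher numbers for weaker inhibition), compound 2 gives 20900 nM, which is the highest of the three numbers, meaning the weakest inhibition. The nearest is compound 1 at 8560 nM, and the step from compound 1 to compound 2 is a 2.4-fold higher number from compound 1 to compound 2 (0.39 log units; beyond the scatter). The furthest is compound 3 at 7040 nM, reached by the step of a 3.0-fold lower number from compound 2 to compound 3 (0.47 log units; beyond the scatter).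

Compound 4 `Cc1ccccc1C(=O)Nc1sc2c(c1C(N)=O)CCN(C(=S)Nc1ccccc1Br)C2` has not yet been measured. It differs from compound 2 in one place: bromo in place of chloro on an aromatic carbon. Within the data shown here, none of the measured steps changes this part of the molecule; all three concern the group on the carbonyl carbon, so no step bears directly on the exchange of one halogen for another on the thiourea side. Because a 1.2-fold lower number from compound 1 to compound 3 (0.08 log units; within the scatter) and the other steps are modest or within the scatter even for larger changes elsewhere, a halogen swap of this kind is expected to move the number little. The expected step is a 1.2-fold lower number from compound 2 to compound 4 (0.06 log units; within the scatter), and compound 4 is therefore estimated at 18000 nM, with a range from 8000 nM to 45000 nM.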

Compound 4, half-maximal inhibitory concentration: 45200 nM
Compound 4: the middle estimate sits 2.5-fold (0.40 log units) below what was measured; measured number outside the range, above it.
By their numbers in this assay, from the lowest: compounds 3 and 1 (each within the scatter of the next); then compound 2; then compound 4.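

In this assay, the halogen on the thiourea aryl ring turns out to matter: putting bromo in place of chloro, on an aromatic carbon ortho to a large group, gives a 2.2-fold higher number from compound 2 to compound 4 (0.33 log units; beyond the scatter). Among these compounds, all the earlier steps concerned the aromatic group on the carbonyl carbon, so this is the only view of this side of the molecule, and it shows that exchanging one heavy atom for another, with no hydrogen-bond donor or acceptor gained or lost, can produce a step in the same modest class as a 2.4-fold higher number from compound 1 to compound 2 (0.39 log units; beyond the scatter). Nothing available here accounts for the direction of this change.

From the compounds shown here alone, the chloro-to-bromo change is seen on a single pair carrying the 2-methylphenyl group, so it remains open whether the same step would appear with the 2-iodophenyl group of compound 1 or the 3-nitrophenyl group of compound 3. Also open, going by these compounds, is how fluoro, methoxy or an amine at this same place on the ring would compare with chloro and bromo, and so whether the number follows any trend across such groups.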